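The compounds below may be only part of what the source reports. "The series", "measured", "known", "first", "only" and "open" are said of these compounds alone.

Measured compounds in a functional assay on Caco-2 cells (Homo sapiens) for antiproliferative activity, read by MTT assay, with a stated time of 48 h; on this read-out higher numbers stand for weaker inhibition and lower numbers for stronger inhibition:
- compound 1, `CCn1c(C(=O)NCCCN(C)C)ccc1C(CC)(CC)c1ccc(OCCC(O)(CC)CC)c(C)c1`: 490 nM
- compound 2, `CCn1c(C(=O)N(CCC#N)CCC#N)ccc1C(CC)(CC)c1ccc(OCCC(O)(CC)CC)c(C)c1`: > 50000 nM
- compound 3, `C#CCCOC(=O)c1ccc(C(CC)(CC)c2ccc(OCCC(O)(CC)CC)c(C)c2)n1CC`: > 50000 nM

Compound 3, `C#CCCOC(=O)c1ccc(C(CC)(CC)c2ccc(OCCC(O)(CC)CC)c(C)c2)n1CC`, stands at the limit of this assay, where its value of > 50000 nM is a limit and not a number. Compound 2 sits at the same limit, its value of > 50000 nM being a limit as well, so that (the limit of > 50000 nM in this assay, at which 2 of the 3 values shown sit). Compound 1 is the only one of the three with a number, 490 nM.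

Compound 4, `CCn1c(C(=O)NC(C)C(=O)O)ccc1C(CC)(CC)c1ccc(OCCC(O)(CC)CC)c(C)c1`, differs from compound 3 in one place: (1-carboxyethyl)amino in place of (but-3-yn-1-yl)oxy on a carbonyl carbon. For the measured compounds named here, two measured steps bear on this change. Replacing the (3-(dimethylamino)propyl)amino group of compound 1 gave an at least 100-fold higher number from compound 1 to compound 3 (2.00 log units; beyond the scatter) and an at least 100-fold higher number from compound 1 to compound 2 (2.00 log units; beyond the scatter), both large and both ending at the limit. The step from compound 2 to compound 3, a step that the two limits leave unreadable from compound 2 to compound 3, cannot be read. Compound 4 returns to a carbamoyl group, but with (1-carboxyethyl)amino rather than the (3-(dimethylamino)propyl)amino of compound 1, so the expectation is for compound 4 to remain weak. The estimated step for compound 4 is therefore an at least 1.4-fold lower number from compound 3 to compound 4 (0.15 log units; that floor lies within the scatter), with the number likely again a limit. The estimate for compound 4 in this assay is 35000 nM, expected between 5000 nM and 100000 nM.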

Compound 4, half-maximal inhibitory concentration: 46500 nM
Compound 4: middle estimate off by 1.3-fold (0.12 log units), on the low side, within the range that was stated.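

Compound 1 and compound 4 both keep the amide hydrogen, yet in this assay 1-carboxyethyl in place of 3-(dimethylamino)propyl on the amide-type nitrogen gives a 95-fold higher number from compound 1 to compound 4 (1.98 log units; beyond the scatter), so a carbamoyl group on this carbonyl carbon does not by itself carry the activity of compound 1. Compared with the two compounds at the limit, the result gives an at least 1.0-fold lower number from compound 3 to compound 4 (0.03 log units; that floor lies within the scatter) and an at least 1.0-fold lower number from compound 2 to compound 4 (0.03 log units; that floor lies within the scatter), and as these floors lie within the scatter, compound 4 cannot be set apart from compound 2 or compound 3. The values of compound 2 and compound 3 remain limits and not numbers, so the ester and the two amides without 3-(dimethylamino)propyl cannot be ranked against one another: the limit of > 50000 nM in this assay, at which 2 of the 4 values shown sit.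

The compounds shown leave open whether the activity of compound 1 follows the terminal dimethylamino group or the propyl chain that carries it. An amide ending in a primary amine, one with a shorter or longer chain before the dimethylamino group, or one with a longer chain ending in a carboxylic acid would separate these readings.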